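Naphthalen-1-yl for 4-formylphenyl on the benzyl-bearing core

This account rests on a few compounds, and the source may have more. Where it says the series, first, only, none or still open, it means among the compounds named here.

Compound 1 `O=Cc1ccc(-c2cn3ccnc3c(-c3ccc4ncn(C5CCCCC5)c4c3)n2)cc1` gives 25.3% in a functional assay on NCI-H522 cells (Homo sapiens) for inhibition, read by sulforhodamine B assay, with a stated time of 48 h, tested at 10 uM; on this read-out higher numbers stand for more inhibition at the one concentration tested (going by the name of the read-out) and lower numbers for less inhibition. Compound 2 `c1ccc2c(-c3cn4ccnc4c(-c4ccc5ncn(C6CCCCC6)c5c4)n3)cccc2c1` gives 19.3% in this assay; the change is naphthalen-1-yl in place of 4-formylphenyl on an aromatic carbon, and the step is a number 6 percentage points lower from compound 1 to compound 2 (within the scatter). Compound 3 `O=Cc1ccc(-c2cn3ccnc3c(-c3ccc4ncn(Cc5ccccc5)c4c3)n2)cc1` gives 25.3% in this assay; it differs from compound 1 by benzyl in place of cyclohexyl on an aromatic nitrogen, with a step of no change at the digits printed from compound 1 to compound 3 (within the scatter). Compound 4 `c1ccc(Cn2cnc3ccc(-c4nc(-c5cccc6ccccc56)cn5ccnc45)cc32)cc1` remains to be measured in this assay; it differs from compound 3 by naphthalen-1-yl in place of 4-formylphenyl on an aromatic carbon, the same change as from compound 1 to compound 2, the two places being described in the same words. The step expected from compound 3 to compound 4 is estimated as a number 5.3 percentage points lower from compound 3 to compound 4 (within the scatter), because a number 6 percentage points lower from compound 1 to compound 2 (within the scatter) lay within the scatter. Compound 4 is therefore expected to give about 20% in this assay. For compound 4 the estimated range runs from 8% to 32%.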

Compound 4, a percentage reported as inhibition, at one concentration (the size of the read-out at that concentration, not a potency): 29.3%
Compound 4: the middle estimate sits 9.3 percentage points below what was measured; the measured number falls inside the stated range.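

In this assay naphthalen-1-yl in place of 4-formylphenyl on the benzyl-bearing core gives a number 4 percentage points higher from compound 3 to compound 4 (within the scatter) and the result does not separate from that on the cyclohexyl-bearing core: the same change on two cores in this assay, a number 6 percentage points lower (within the scatter) from compound 1 to compound 2 and a number 4 percentage points higher (within the scatter) from compound 3 to compound 4, 10 percentage points apart, within the scatter of two such steps.
Benzyl in place of cyclohexyl on the aromatic nitrogen gives a number 10 percentage points higher from compound 2 to compound 4 (within the scatter) and this change also shows no difference between the two cores: the same change on two cores in this assay, no change at the digits printed (within the scatter) from compound 1 to compound 3 and a number 10 percentage points higher (within the scatter) from compound 2 to compound 4, 10 percentage points apart, within the scatter of two such steps.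
Both changes therefore carry across these two cores with no detectable difference, but that does not show that either change has a real effect of its own or that the steps would hold on any other core in the series.

The compounds shown leave open whether an amine or a carboxylic acid in place of 4-formylphenyl, or a longer chain on the aromatic nitrogen, would give a step beyond the scatter.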